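A Chloro-to-Methyl Swap Repeated on a Second Core

The source may hold more compounds than are shown below. What is called first, only, known or untested is meant among the compounds shown, and "the series" means these compounds.

Measured compounds:
Compound 1, `O=C(Nc1nnc(-c2ccc(Cl)cc2)s1)c1ccccc1`, 4850 nM
Compound 2, `Cc1ccc(-c2nnc(NC(=O)c3ccccc3)s2)cc1`, 3570 nM
Compound 3, `O=C(Nc1nnc(-c2ccccc2)s1)c1ccc(Cl)cc1`, 4490 nM

The three measured compounds were tested in a functional assay on MCF7 cells (Homo sapiens) for antiproliferative activity, read by MTT assay, with a stated time of 48 h; on this read-out lower numbers stand for stronger inhibition and higher numbers for weaker inhibition. Compound 1 gives 4850 nM, compound 2 gives 3570 nM and compound 3 gives 4490 nM. Among the compounds with values here, all three numbers sit close together, and no pair of them is separated by more than the usual scatter.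

Compounds 1 and 2 differ in one place, (methyl in place of chloro on an aromatic carbon), and the step that this change made is a 1.4-fold lower number from compound 1 to compound 2 (0.13 log units; within the scatter). Compound 4, `Cc1ccc(C(=O)Nc2nnc(-c3ccccc3)s2)cc1`, has not yet been measured. It stands to compound 3 as compound 2 stands to compound 1: the change is methyl in place of chloro on an aromatic carbon, and the place is described in the same words, so this is the same change applied on a second core. Compound 1 and compound 3 are built from the same atoms joined differently, but the difference between the two cores is not broken down here.

Within the data shown here, since the only measured instance of this change, from compound 1 to compound 2, stayed within the scatter, compound 4 is expected to land near compound 3, with an estimated step of a 1.2-fold lower number from compound 3 to compound 4 (0.10 log units; within the scatter). The estimate for compound 4 in this assay is 3600 nM, with a range from 1600 nM to 8000 nM; this rests on compound 3 at 4490 nM and on the step of a 1.4-fold lower number from compound 1 to compound 2 (0.13 log units; within the scatter).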

Compound 4, half-maximal inhibitory concentration: 3280 nM
The estimate for compound 4 lay 1.1-fold (0.04 log units) above the measured number; the measured number falls inside the stated range.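

In this assay, putting methyl in place of chloro on the second core gave a 1.4-fold lower number from compound 3 to compound 4 (0.14 log units; within the scatter), so the change left the number within the scatter here, just as it did on the first core. Set side by side, the two steps agree, and the change behaved alike on both cores: the same change on two cores in this assay, a 1.4-fold lower number (0.13 log units; within the scatter) from compound 1 to compound 2 and a 1.4-fold lower number (0.14 log units; within the scatter) from compound 3 to compound 4, 1.0-fold (0.00 log units) apart, within the scatter of two such steps
Within the data shown here, this agreement is a modest finding, since both steps are small enough to be lost in repeated measurement, so it shows only that neither core responded to the swap with a shift beyond the scatter; it does not show that methyl gives stronger inhibition than chloro on either core, nor that a step of real size would carry from one core to the other, and two cores in a single cell assay cannot establish a rule for the series.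

The compounds shown leave open whether any other group in this place, such as an amine, a carboxylic acid or a longer chain, would move the number beyond the scatter. They also leave open whether such a step, if one exists, would match on the two cores.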